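This account rests on a few compounds, and the source may have more. Where it says the series, first, only, none or still open, it means among the compounds named here.

Compounds measured in a physicochemical assay for solubility, read by HPLC, in phosphate buffer, measured as kinetic solubility, at pH 7.4; on this read-out lower numbers stand for lower solubility and higher numbers for higher solubility:
Compound 1 `CCC(=O)c1cc(-c2ccc(Cl)cc2)[nH]c1C` gives 900 nM
Compound 2 `CCOC(=O)c1cc(-c2ccc(Cl)cc2)n(-c2ccc(S(N)(=O)=O)cc2)n1` gives 53300 nM
Compound 3 `CC(=O)c1cc(-c2ccc(S(N)(=O)=O)cc2)n(-c2ccc(Cl)cc2)n1` gives 86800 nM

Compound 3, at 86800 nM on this scale, sits at the top of this small set together with compound 2, whose 53300 nM lies within the scatter of it. Compound 1 stands apart, with 900 nM as a number far lower than both and beyond the scatter.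

The next compound is compound 4 `NS(=O)(=O)c1ccc(-c2cc(C(=O)C3CCCC3)nn2-c2ccc(Cl)cc2)cc1` which differs from compound 3 in one place: cyclopentyl in place of methyl on a carbonyl carbon, or acetyl to cyclopentylcarbonyl if the cut is made one bond further out. Counted out, the change reads cyclopentyl in place of methyl on a carbonyl carbon and the rest of the structure stays the same.

Among the measured compounds shown here, no two measured compounds differ in only one place, so nothing here shows directly what such a swap does in this assay and any forecast is uncertain. Even so, a lower number than for compound 3 is expected, in a step beyond the scatter. In size, the expected change is a 5.8-fold lower number from compound 3 to compound 4 (0.76 log units; beyond the scatter) by this estimate. For compound 4 the estimated value is 15000 nM with 3000 nM to 60000 nM as the expected span.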

Compound 4, solubility: 4600 nM
Compound 4: the middle estimate sits 3.3-fold (0.51 log units) above what was measured; low and high end bracket the measured number.
By their numbers in this assay, from the lowest: compound 1; then compound 4; then compounds 2 and 3 (each within the scatter of the next).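

In this assay, among the compounds shown here, putting cyclopentyl in place of methyl on a carbonyl carbon gives a 19-fold lower number from compound 3 to compound 4 (1.28 log units; beyond the scatter) and this is the first reading in the set of a change made in one place only, since the earlier compounds differ from each other in more than one place. The step is large and beyond the scatter, so what sits on this carbonyl carbon clearly matters on this read-out, at least in this pair. The whole difference is 1 heavy atom of carbon leaving and 5 entering as a five-membered non-aromatic ring of carbon only, with no hydrogen-bond donors or acceptors on either side, and nothing measured here says which aspect of that exchange accounts for the step.

On these data alone, with a single step at this position, it stays open whether the ring itself or simply the larger number of carbons goes with the lower number, which an open chain such as propyl or a branched group such as tert-butyl could help to separate. Also open, as far as these compounds go, is where the number would land with an amine or a carboxylic acid built into the group on this carbonyl carbon.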